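The source may hold more compounds than are shown below. What is called first, only, known or untested is meant among the compounds shown, and "the series" means these compounds.

In a physicochemical assay for solubility, in phosphate buffer, at pH 7.4; a lower number here means a less soluble compound, a higher number a more soluble compound:
- Compound 1 `CN(C)C1CCN(c2nccnc2OC2CN(c3ccc4ccccc4n3)C2)CC1`: 500000 nM
- Compound 2 `c1ccc2nc(N3CC(Oc4nccnc4-c4cncnc4)C3)ccc2c1`: 254000 nM

Among the compounds with values here, compound 2 stands within the scatter of compound 1, the only other measured compound, so the two cannot be ranked. Compound 3 `COC(=O)N1CCC(c2nccnc2OC2CN(c3ccc4ccccc4n3)C2)CC1` has not yet been measured. It differs from compound 2 as follows: 1-(methoxycarbonyl)piperidin-4-yl in place of pyrimidin-5-yl on an aromatic carbon. In words, 1-(methoxycarbonyl)piperidin-4-yl takes the place of pyrimidin-5-yl on an aromatic carbon, next to the ring nitrogen.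

Within the data shown here, one measured step bears on this place, the exchange of 4-(dimethylamino)piperidin-1-yl for pyrimidin-5-yl: a 2.0-fold lower number from compound 1 to compound 2 (0.29 log units; within the scatter). That single step stays within the scatter and gives no sign of a large change. Among the measured compounds shown here, no measured compound carries 1-(methoxycarbonyl)piperidin-4-yl, so the size of the new step remains open. For the measured compounds named here, a modest move to a lower number in this assay is expected, a judgement that no measured step supports. The expected step is a 2.5-fold lower number from compound 2 to compound 3 (0.40 log units; beyond the scatter). For compound 3 the estimate is 100000 nM, with an expected range from 20000 nM to 350000 nM.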

Compound 3, solubility: 138000 nM
Estimate against measurement, compound 3: 1.4-fold (0.14 log units) below, and the stated range covers the measured number.
By their numbers in this assay, from the lowest: compounds 3, 2 and 1 (each within the scatter of the next, the first and the last beyond it).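

In this assay, the place on an aromatic carbon, next to the ring nitrogen, now carries a six-membered non-aromatic ring as well as an aromatic one, and 1-(methoxycarbonyl)piperidin-4-yl in place of pyrimidin-5-yl gives a 1.8-fold lower number from compound 2 to compound 3 (0.26 log units; within the scatter), so this exchange cannot be told apart from repeated measurement. Set against 4-(dimethylamino)piperidin-1-yl at the same place, the same group gives a 3.6-fold lower number from compound 1 to compound 3 (0.56 log units; beyond the scatter), the first step at this place that lies beyond the scatter, and it shows that the groups tried here do separate in this assay, though only modestly and only between compound 1 and compound 3, with compound 2 within the scatter of both. No measurement is available that would explain either step.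

The compounds shown leave open whether the step from compound 1 to compound 3 follows from the methoxycarbonyl or from the ring that carries it, which a piperidin-4-yl with a free amine at the same aromatic carbon would help to separate. They also leave open how a carboxylic acid or a longer chain at this place would read in this assay.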